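The compounds below may be only part of what the source reports. "The series", "measured", "known", "first", "only" and "open" are said of these compounds alone.

Measured so far (a functional assay on HeLa cells (Homo sapiens) for cytotoxicity, read by resazurin assay; a lower number here means a stronger inhibitor, a higher number a weaker inhibitor):
Compound 1 `C#Cc1cccc(Nc2ncnc3cc(NC(=O)c4ccc(C(=O)Nc5ccccc5N)cc4)ccc23)c1` gives 1700 nM here
Compound 2 `C#Cc1cccc(Nc2ncnc3ccc(NC(=O)c4ccc(C(=O)Nc5ccccc5N)s4)cc23)c1` gives > 50000 nM here, a limit and not a number
Compound 3 `C#Cc1cccc(Nc2ncnc3ccc(OCc4ccc(C(=O)Nc5ccccc5N)cc4)cc23)c1` gives 1350 nM here

Compound 3 and compound 1 lie within the usual scatter of each other, so the two stand level. Compound 4 `Nc1ccccc1NC(=O)c1ccc(COc2ccc3ncnc(Nc4cccc(Br)c4)c3c2)cc1` differs from compound 3 in one place, with bromo in place of ethynyl on an aromatic carbon. Among the compounds with values here, no measured pair of compounds shows this swap, so the expectation rests on compound 3 at 1350 nM and no change beyond the scatter is expected in this assay. The estimated shift (a 1.1-fold higher number from compound 3 to compound 4 (0.05 log units; within the scatter)) is expected to stay small. Compound 4 is expected at 1500 nM (estimated range 500 nM to 5000 nM).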

Compound 4, half-maximal inhibitory concentration: 1450 nM
The estimate for compound 4 lay 1.0-fold (0.01 log units) above the measured number; measured number inside the range.
By their numbers in this assay, from the lowest: compounds 3, 4 and 1 (each within the scatter of the next). At a limit, above all of these: compound 2.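

In this assay, going from 3-ethynylphenyl to 3-bromophenyl gives a 1.1-fold higher number from compound 3 to compound 4 (0.03 log units; within the scatter), so the two compounds stand level. Within the data shown here, this is the first measured swap at this position, and it shows that ethynyl, with its triple bond, can give way to a single bromine atom on this aromatic carbon without leaving the scatter. Nothing measured here gives a reason for this result.

On these data alone, how an amine, a carboxylic acid or a longer chain at this place would read in this assay remains open. As far as these compounds go, whether the same swap stands level on the core of compound 1 is also open.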